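Replacing the seven-membered ring of compound 3

The source may report more compounds than this note shows. Statements on the series, on what has been measured and on what is new or still open speak of the compounds shown alone.

Measured in a physicochemical assay for solubility, in phosphate buffer, at pH 7.4; on this read-out lower numbers stand for lower solubility and higher numbers for higher solubility:
- compound 1 `CC(=O)N[C@@H]1CCC[C@H](C(=O)Nc2cc(-c3nnn4ccccc34)c(Cl)cn2)C1` gives 530000 nM
- compound 2 `CC(=O)N[C@@H]1CCC[C@H](C(=O)Nc2cc(-c3cnn4c3CCC4)c(Cl)cn2)C1` gives 160000 nM
- compound 3 `CC(=O)N[C@@H]1CCC[C@H](C(=O)Nc2cc(-c3cnn4c3CCCCC4)c(Cl)cn2)C1` gives 104000 nM

Compound 3 stands at the low end of these numbers together with compound 2, since a 1.5-fold lower number from compound 2 to compound 3 (0.19 log units; within the scatter) stays within the scatter. Compound 1 stands highest, and a 5.1-fold lower number from compound 1 to compound 3 (0.71 log units; beyond the scatter) lies beyond the scatter.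

The next compound, compound 4 (`CC(=O)N[C@@H]1CCC[C@H](C(=O)Nc2cc(-c3cnn4c3COCC4)c(Cl)cn2)C1`), differs from compound 3 in one group: a group of 9 heavy atoms (6 carbon, 2 nitrogen, 1 oxygen; one five-membered aromatic ring with 2 hetero atoms, one six-membered non-aromatic ring with 2 hetero atoms) in place of a group of 10 heavy atoms (8 carbon, 2 nitrogen; one five-membered aromatic ring with 2 hetero atoms, one seven-membered non-aromatic ring with 1 hetero atom), on an aromatic carbon.

Two kinds of measured step bear on this. A change in the size of the non-aromatic ring, seen in a 1.5-fold lower number from compound 2 to compound 3 (0.19 log units; within the scatter), gives no ground for a large step. The modest steps away from compound 1, a 3.3-fold lower number from compound 1 to compound 2 (0.52 log units; beyond the scatter) and a 5.1-fold lower number from compound 1 to compound 3 (0.71 log units; beyond the scatter), mark the widest spread so far. Among the compounds with values here, no measured step shows what an oxygen in the non-aromatic ring does, so the expectation is tentative.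

A modest rise is expected, namely a 2.2-fold higher number from compound 3 to compound 4 (0.34 log units; beyond the scatter) in this assay as an estimate. Compound 4 is estimated at 230000 nM (expected range 100000 nM to 500000 nM).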

Compound 4, solubility: 220000 nM
Compound 4: middle estimate off by 1.0-fold (0.02 log units), on the high side; low and high end bracket the measured number.
By their numbers in this assay, from the lowest: compounds 3, 2 and 4 (each within the scatter of the next, the first and the last beyond it); then compound 1.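

In this assay, within the data shown here, the six-membered non-aromatic ring with 2 hetero atoms, on the aromatic carbon opposite the ring nitrogen, gives the first step beyond the scatter among the groups with a non-aromatic ring (a 2.1-fold higher number from compound 3 to compound 4 (0.33 log units; beyond the scatter)). Its distance from the five-membered non-aromatic ring stays within the scatter (a 1.4-fold higher number from compound 2 to compound 4 (0.14 log units; within the scatter)), while compound 1 keeps the highest number, still beyond the scatter (a 2.4-fold lower number from compound 1 to compound 4 (0.38 log units; beyond the scatter)). No measurement at hand accounts for these steps.

Because ring size and the ring oxygen change together from compound 3 to compound 4, the compounds shown cannot separate the two. They also leave open how this position would respond to an amine in place of the ring oxygen, or to a hydroxyl group on the non-aromatic ring.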